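Working notes: substituent exchange on the shared core

A few compounds are considered here, and "the series" means these few. Any claim that something is new, unique, unknown or untested is made for them only; others in the source may bear on it.

Measured so far in an assay on CHO cells for agonist activity at Glucose-dependent insulinotropic receptor (Homo sapiens), read by a luciferase reporter and cAMP accumulation, with a stated time of 2 h; a higher number here means that more compound is needed for the effect, a lower number that less compound is needed:
- compound 1 `CC(C)c1noc(N2CCC(Oc3cc(N4CCc5cc(C6CCCCC6=O)ccc54)ncn3)CC2)n1` gives 48 nM
- compound 2 `CC(C)SC(=O)N1CCC(Oc2cc(N3CCc4ccccc43)ncn2)CC1` reports only a limit of the assay, > 10000 nM
- compound 3 `CC(C)SC(=O)N1CCC(Oc2cc(N3CCc4cc(S(C)(=O)=O)ccc43)ncn2)CC1` gives 3.2 nM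

Compound 1 stands with the highest of the two numbers; its nearest neighbour is compound 3, whose lower value lies beyond the scatter. Compound 2 sits at the limit of the assay and contributes no number (the limit of > 10000 nM in this assay, at which 1 of the 3 values shown sits).

The compound still to be measured is compound 4 `CC(C)c1noc(N2CCC(Oc3cc(N4CCc5cc(N6CCC(O)CC6=O)ccc54)ncn3)CC2)n1`. Its difference from compound 1 is 4-hydroxy-2-oxopiperidin-1-yl in place of 2-oxocyclohexyl on an aromatic carbon. Going by the values given here, the only measured step at the same aromatic carbon is an at least 3100-fold lower number from compound 2 to compound 3 (3.49 log units; beyond the scatter), in which methylsulfonyl enters where hydrogen stood. That step shows the position itself is consequential for this assay. The change to compound 4, however, exchanges one six-membered non-aromatic ring for another bearing a ring nitrogen, a second hydrogen-bond acceptor and one hydrogen-bond donor, rather than introducing a substituent where none was; a step as large as the measured one is therefore not expected. A moderate move toward a lower number is expected, a 2.4-fold lower number from compound 1 to compound 4 (0.38 log units; beyond the scatter), keeping compound 4 between compound 1 and compound 3. Compound 4 is estimated at 20 nM, with a range of 5 nM to 80 nM.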

Compound 4, half-maximal effective concentration: 89 nM
Compound 4: middle estimate off by 4.5-fold (0.65 log units), on the low side; the measured number lies above the stated range.
By their numbers in this assay, from the lowest: compound 3; then compounds 1 and 4 (each within the scatter of the next). At a limit, above all of these: compound 2.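

In this assay the exchange of 2-oxocyclohexyl for 4-hydroxy-2-oxopiperidin-1-yl on this aromatic carbon gives a 1.9-fold higher number from compound 1 to compound 4 (0.27 log units; within the scatter), so the two groups cannot be told apart by this read-out. The earlier compounds shown here compared only hydrogen with methylsulfonyl at this carbon and gave no view of one six-membered non-aromatic ring replacing another; this pair shows that a ring nitrogen and a hydroxyl can enter together without a change beyond the scatter, at least on the core of compound 1. No measured evidence here accounts for why the two groups read alike.

From the compounds shown here alone, the pair changes the ring nitrogen and the hydroxyl in one step, so the contribution of each remains open, and a plain 2-oxopiperidin-1-yl group or a 4-hydroxycyclohexyl ring would separate them. Also open is whether the position accepts groups of another kind on this core, such as a primary amine, a carboxylic acid or a longer open alkyl chain, since only the six-membered rings are shown here.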